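The compounds below may be only part of what the source reports. "The series", "measured", "known", "first", "only" and "open" are said of these compounds alone.

In a functional assay on K562 cells (Homo sapiens) for antiproliferative activity, with a stated time of 72 h (on this read-out lower numbers stand for stronger inhibition and higher numbers for weaker inhibition), compound 1 `OC[C@H]1O[C@@H](n2cnc3c(NCc4cccc(F)c4)ncnc32)[C@H](O)[C@@H]1O` gives 7600 nM and compound 2 `OC[C@H]1O[C@@H](n2cnc3c(NCc4cccc(Br)c4)ncnc32)[C@H](O)[C@@H]1O` gives 19700 nM, which is a 2.6-fold higher number from compound 1 to compound 2 (0.41 log units; beyond the scatter). Compound 3 `COc1ccc(CNc2ncnc3c2ncn3[C@@H]2O[C@H](CO)[C@@H](O)[C@H]2O)c(OC)c1` returns only a limit of the assay, > 166000 nM. The steps into it are an at least 21-fold higher number from compound 1 to compound 3 (1.33 log units; beyond the scatter) and an at least 8.4-fold higher number from compound 2 to compound 3 (0.92 log units; beyond the scatter). Compound 4 `OC[C@H]1O[C@@H](n2cnc3c(NCc4ccc(F)cc4Cl)ncnc32)[C@H](O)[C@@H]1O` carries 2-chloro-4-fluorophenyl in place of 2,4-dimethoxyphenyl on a saturated chain carbon bound to a nitrogen on an aromatic ring. This change replaces the dimethoxy ring with a halogen-bearing ring, as in the reverse of those two steps, so they are the ones that bear on it. In this assay the expected step is an at least 11-fold lower number from compound 3 to compound 4 (1.04 log units; beyond the scatter), large and towards lower numbers. For compound 4 the estimated value is 15000 nM, with an expected range of 5000 nM to 50000 nM.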

Compound 4, half-maximal inhibitory concentration: 15600 nM
Compound 4: the middle estimate sits 1.0-fold (0.02 log units) below what was measured; the range from low to high includes it.
By their numbers in this assay, from the lowest: compound 1; then compounds 4 and 2 (each within the scatter of the next). At a limit, above all of these: compound 3.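

With 2-chloro-4-fluorophenyl on this saturated chain carbon, the read-out returns to a measurable value, an at least 10-fold lower number from compound 3 to compound 4 (1.02 log units; beyond the scatter), so a ring with two substituents is tolerated here when both are halogens. Compound 3 remains a limit of the assay, not a number: the limit of > 166000 nM in this assay, at which 1 of the 4 values shown sits. Among the halogen-bearing rings the steps stay small, with a 1.3-fold lower number from compound 2 to compound 4 (0.10 log units; within the scatter) and a 2.1-fold higher number from compound 1 to compound 4 (0.31 log units; beyond the scatter).

Whether a single methoxy alone accounts for the loss at compound 3 remains open. So does what an amine or a carboxylic acid on this ring would give.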